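Phenyl on a ring nitrogen, starting from a limit

The compounds below may be only part of what the source reports. "The series", "measured", "known", "first", "only" and "open" are said of these compounds alone.

Measured so far in a functional assay on MCF7 cells (Homo sapiens) for antiproliferative activity, read by MTT assay, with a stated time of 72 h (a lower number here means a stronger inhibitor, a higher number a weaker inhibitor), are two compounds:
Compound 1 `O=C1COc2ccc(-c3cnc(Cl)c(NS(=O)(=O)c4ccc(F)cc4)c3)cc2N1C1CCCCC1` gives > 40000 nM as a limit
Compound 2 `O=C1COc2ccc(-c3cnc(Cl)c(NS(=O)(=O)c4ccc(F)cc4)c3)cc2N1` gives > 40000 nM as a limit

Compound 2 therefore stands at a limit and has no number, and it shares the limit of > 40000 nM in this assay, at which 2 of the 2 values shown sit, with compound 1. Compound 3 `O=C1COc2ccc(-c3cnc(Cl)c(NS(=O)(=O)c4ccc(F)cc4)c3)cc2N1c1ccccc1` differs from compound 2 by phenyl in place of hydrogen on an amide-type nitrogen in a ring and so carries phenyl in place of hydrogen on an amide-type nitrogen in a ring. For the measured compounds named here, the one measured step at that nitrogen is a step that the two limits leave unreadable from compound 1 to compound 2 and it offers no size to carry over. No change beyond the scatter is therefore expected in this assay and the expected step is a number no higher from compound 2 to compound 3 (the limit leaves the size open) in this account. The estimate for compound 3 is 40000 nM with an expected range from 15000 nM to 80000 nM and a report of only a limit is likely.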

Compound 3, half-maximal inhibitory concentration: > 40000 nM
Compound 3: only a limit was reported (the forecaster's own chance of this, stated with the estimate: 75%); the middle value lies on the limit itself.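

No step can be read among compound 1, compound 2 and compound 3, which each give only a limit in this assay: the limit of > 40000 nM in this assay, at which 3 of the 3 values shown sit. From the compounds shown here alone, how hydrogen, cyclohexyl and phenyl on the amide-type nitrogen compare in this assay stays open.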